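Swapping methyl for nitro on a weakly active sulfonate

The compounds below may be only part of what the source reports. "The series", "measured", "known", "first", "only" and "open" are said of these compounds alone.

Measured in a functional assay on M21 cells (Homo sapiens) for antiproliferative activity, read by sulforhodamine B assay, with a stated time of 48 h; on this read-out higher numbers stand for weaker inhibition and lower numbers for stronger inhibition:
- compound 1 `CN1CCN(c2ccc(S(=O)(=O)Oc3cccc([N+](=O)[O-])c3)cc2)C1=O`: 23000 nM
- compound 2 `CCCN1CCN(c2ccc(S(=O)(=O)Oc3ccccc3CC)cc2)C1=O`: > 50000 nM (a limit)
- compound 3 `CCCN1CCN(c2ccc(S(=O)(=O)Oc3cccc(C)c3)cc2)C1=O`: 28000 nM

In this assay compound 3 gives 28000 nM, and compound 1 gives 23000 nM, so the two lie within the usual scatter of each other. The value of compound 2 is a limit, not a number, as the limit of > 50000 nM in this assay, at which 1 of the 3 values shown sits, records.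

Compound 4 `CCCN1CCN(c2ccc(S(=O)(=O)Oc3cccc([N+](=O)[O-])c3)cc2)C1=O` differs from compound 3 by one change: nitro in place of methyl on an aromatic carbon, meta to a large group (nitro in place of methyl on an aromatic carbon).

Going by the values given here, the one measured step, an at least 1.7-fold lower number from compound 2 to compound 3 (0.25 log units; that floor lies within the scatter), concerns a different swap, 3-methylphenyl in place of 2-ethylphenyl on an oxygen, so it bears only loosely. Closer evidence comes from compound 1, which already carries 3-nitrophenyl and gives 23000 nM. On that ground, no change beyond the scatter is expected in this assay.

The expected step is a 1.1-fold lower number from compound 3 to compound 4 (0.05 log units; within the scatter). For compound 4 the estimated value is 25000 nM, with an expected range of 12000 nM to 50000 nM.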

Compound 4, half-maximal inhibitory concentration: 38000 nM
Beside the measured number, compound 4's estimate is 1.5-fold (0.18 log units) below it; measured number inside the range.
By their numbers in this assay, from the lowest: compounds 1, 3 and 4 (each within the scatter of the next). At a limit, above all of these: compound 2.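

In this assay, nitro in place of methyl on this aromatic carbon, meta to a large group, gives a 1.4-fold higher number from compound 3 to compound 4 (0.13 log units; within the scatter) and so shows no change that can be told from the scatter, even though the two groups differ in size and in hydrogen-bond acceptors. With 3-nitrophenyl held fixed, ethyl in place of hydrogen on the chain at the amide-type nitrogen gives a 1.7-fold higher number from compound 1 to compound 4 (0.22 log units; within the scatter) and likewise stays within the scatter. The comparison with the 2-ethylphenyl compound gives only a floor in an at least 1.3-fold lower number from compound 2 to compound 4 (0.11 log units; that floor lies within the scatter) as the value of compound 2 is a limit: the limit of > 50000 nM in this assay, at which 1 of the 4 values shown sits.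

On these data alone, what an amine or a carboxylic acid would do on this aromatic carbon remains open. So does the effect of a longer chain on the amide-type nitrogen.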